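Ester to propargyl amide on the shared core

The source may report more compounds than this note shows. Statements on the series, on what has been measured and on what is new or still open speak of the compounds shown alone.

For the measured compounds named here, the series so far holds two measured compounds on one core. Compound 1 `CCCC(=O)OCSc1ccccc1C(=O)N[C@H]1CCC[C@@H]1C(N)=O` carries a cyclopentane carboxamide on the benzamide nitrogen; in an ADME assay on CEM-SS cells (Homo sapiens) for cytotoxicity, read by XTT assay, with a stated time of 6 days (a lower number here means that less compound is tolerated, a higher number that more compound is tolerated), compound 1 gives 31.2 uM; 43.3 uM (2 entries), and the spread of those repeats, (the several entries of compound 1 in this assay, 31.2 uM; 43.3 uM (2 entries)), falls inside the usual scatter. Going by the values given here, compound 2 `CCCC(=O)OCSc1ccccc1C(=O)NCC(=O)OC` carries a glycine methyl ester instead; in this assay compound 2 gives 27.3 uM, the only number recorded for it, with one further entry that yields no single number. The two compounds sit close together on the numbers shown.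

Compound 3 `C#CCNC(=O)CNC(=O)c1ccccc1SCOC(=O)CCC` is not yet measured. It differs from compound 2 by propargylamino in place of methoxy on a carbonyl carbon. Among the compounds with values here, no measured pair in this set spans that kind of change, so there is no step to lean on. With both measured compounds close together in this assay, the expected step of a 1.1-fold higher number from compound 2 to compound 3 (0.04 log units; within the scatter) is small, in no particular direction, and no larger than the scatter of repeats. For compound 3 the value in this assay is estimated at 30 uM, with a plausible range from 12 uM to 75 uM.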

Compound 3, half-maximal toxic concentration: 95.4 uM
Beside the measured number, compound 3's estimate is 3.2-fold (0.50 log units) below it; measured number above the stated range.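

Propargylamino in place of methoxy on a carbonyl carbon gives the first readable step in the series: in this assay it produces a 3.5-fold higher number from compound 2 to compound 3 (0.54 log units; beyond the scatter), with more compound tolerated after the change. This shows that the position is not silent in the cell read-out, a point that two compounds differing in more than one place could not settle. The step also stands apart from what repeat entries of one unchanged structure can show, and the repeat spread for comparison is this one: the several entries of compound 1 in this assay, 31.2 uM; 43.3 uM (2 entries).

The compounds shown leave open which part of the exchange goes with the step, since the single change brings in the amide hydrogen and the triple bond together, and removes the methoxy group as well. A propyl amide, with a saturated chain in place of the propargyl group, or a carboxylic acid on the same carbonyl carbon would help to separate these parts, and one modest step on a single pair gives no trend for the position as a whole.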